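The source may hold more compounds than are shown below. What is called first, only, known or untested is meant among the compounds shown, and "the series" means these compounds.

Values in an ADME assay for pharmacokinetics, at pH 7.4 (a higher number here means that the compound lasts longer, a lower number that the compound disappears faster), for the measured compounds:
- compound 1 `COc1c(C)cnc(C[S+]([O-])c2nc3cc(OC(F)F)ccc3[nH]2)c1C`: 15 h
- compound 2 `COc1ccnc(C[S+]([O-])c2nc3cc(OC(F)F)ccc3[nH]2)c1C`: 3 h
- compound 3 `COc1cc2[nH]c([S+]([O-])Cc3nccc(OC)c3OC)nc2cc1OC(F)F`: 800 h

Compound 3 stands highest of the three, beyond the scatter from both others. Compound 4 `COc1cc2[nH]c([S+]([O-])Cc3nccc(OC)c3C)nc2cc1OC(F)F` differs from it by methyl in place of methoxy on an aromatic carbon. Among the compounds with values here, no measured step makes this exchange. The nearest one, a 5.0-fold lower number from compound 1 to compound 2 (0.70 log units; beyond the scatter), puts hydrogen in place of methyl and is modest, though beyond the scatter. Compound 1 at 15 h and compound 2 at 3 h both hold methyl at this place, but they also differ from compound 3 elsewhere, so they suggest only a direction. In this assay the expected change is a clear drop, estimated as a 10-fold lower number from compound 3 to compound 4 (1.00 log units; beyond the scatter), beyond the scatter. For compound 4 the expected value is 80 h (estimated range 20 h to 300 h).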

Compound 4, half-life: 11 h
For compound 4 the middle estimate is 7.3-fold (0.86 log units) above the measured one; measured number below the stated range.
By their numbers in this assay, from the lowest: compound 2; then compounds 4 and 1 (each within the scatter of the next); then compound 3.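

In this assay the exchange of methoxy for methyl at this place, two atoms from the ring nitrogen, gives a 73-fold lower number from compound 3 to compound 4 (1.86 log units; beyond the scatter) as a large step, well beyond the modest hydrogen-for-methyl step seen earlier. Methoxy in place of hydrogen on an aromatic carbon gives only a 3.7-fold higher number from compound 2 to compound 4 (0.56 log units; beyond the scatter) and so shows that adding a methoxy group does not always bring a large change. From the compounds shown here alone, whether an ethoxy group or an amine at this place would retain the long half-life of compound 3 remains open. No measurement here explains the size of the drop.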